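The compounds below may be only part of what the source reports. "The series", "measured", "known", "first", "only" and "open" are said of these compounds alone.

Measured in a functional assay on MDA-MB-468 cells (Homo sapiens) for antiproliferative activity, read by MTT assay, with a stated time of 24 h; on this read-out lower numbers stand for stronger inhibition and higher numbers for weaker inhibition:
compound 1 `CNC(=O)c1ccccc1Oc1nc(Nc2ccc(C)cc2C)ncc1Br`: 40700 nM
compound 2 `COc1cc(Nc2ncc(I)c(NCCCN)n2)cc(OC)c1OC`: > 50000 nM (a limit, not a number)

Compound 2 stands at > 50000 nM, which is only a limit of this assay. Among the measured compounds shown here, that leaves compound 1 at 40700 nM as the only true number.

Compound 3 `CCN(CC)CCNc1nc(Nc2cc(OC)c(OC)c(OC)c2)ncc1I` has diethylamino in place of aminomethyl on a saturated chain carbon, two bonds along the chain from a nitrogen on an aromatic ring. The same difference reads 3-aminopropyl to 2-(diethylamino)ethyl.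

For the measured compounds named here, no measured pair differs in one place, so this change has no direct precedent here. A small move toward stronger inhibition is expected, not far beyond the usual scatter, and the estimated size is an at least 1.4-fold lower number from compound 2 to compound 3 (0.15 log units; that floor lies within the scatter). With compound 1 at 40700 nM, no strong inhibition is expected. For compound 3 the estimated value is 35000 nM, with an expected range of 12000 nM to 80000 nM.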

Compound 3, half-maximal inhibitory concentration: 32300 nM
For compound 3 the middle estimate is 1.1-fold (0.03 log units) above the measured one; the range from low to high includes it.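

In this assay compound 2 gives > 50000 nM, which is a limit and not a number. Diethylamino in place of aminomethyl on a saturated chain carbon, two bonds along the chain from a nitrogen on an aromatic ring, gives the first one-place comparison in the series, read as an at least 1.5-fold lower number from compound 2 to compound 3 (0.18 log units; that floor lies within the scatter), so this position now carries one true number, in compound 3, but no exact size of change. As far as these compounds go, the real size of the step stays unknown because one end of it is open: the limit of > 50000 nM in this assay, at which 1 of the 3 values shown sits.

The compounds shown leave open how dimethylamino, a morpholine ring or a carboxylic acid would read at the same place. They also leave open how much of the step belongs to the shorter chain and how much to the diethylamino group, as both change together from 3-aminopropyl to 2-(diethylamino)ethyl.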